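Replacing the phenylethyl group with an aminobutyl chain

The compounds below may be only part of what the source reports. "The series", "measured", "known", "first", "only" and "open" are said of these compounds alone.

Compound 1, `CCCCCCCCCCCC(=O)OC[C@H](CSC[C@@H](N)C(=O)NCCO)OC(=O)CCCCCCCCCCC`, gives 24 nM in an assay on HEK293 cells for agonist activity at Toll-like receptor 2 (Homo sapiens); on this read-out higher numbers stand for an effect only at larger amounts of compound and lower numbers for an effect already at smaller amounts.
Compound 2, `CCCCCCCCCCCC(=O)OC[C@H](CSC[C@@H](N)C(=O)NC(C)c1ccccc1)OC(=O)CCCCCCCCCCC`, gives 9900 nM in this assay.
Compound 3, `CCCCCCCCCCCC(=O)OC[C@H](CSC[C@@H](N)C(=O)NC(C)CCC(C)C)OC(=O)CCCCCCCCCCC`, gives 190 nM in this assay.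

Compound 2 stands highest of the three numbers; the nearest is compound 3, the furthest compound 1, and both gaps lie beyond the scatter. Compound 4, `CCCCCCCCCCCC(=O)OC[C@H](CSC[C@@H](N)C(=O)NCCCCN)OC(=O)CCCCCCCCCCC`, differs from compound 2 in one place: 4-aminobutyl in place of 1-phenylethyl on an amide-type nitrogen. Going by the values given here, two measured steps bear on this change. The step of a 410-fold higher number from compound 1 to compound 2 (2.62 log units; beyond the scatter) shows how much the number rises when 1-phenylethyl replaces 2-hydroxyethyl, and the step of a 52-fold lower number from compound 2 to compound 3 (1.72 log units; beyond the scatter) shows that moving away from the phenyl group again brings the number down sharply. The incoming 4-aminobutyl group, like the 2-hydroxyethyl of compound 1, has no ring and carries one hydrogen-bond donor and one acceptor, so a large fall in this assay is expected, closer to compound 1 than to compound 3. Compound 4 is therefore estimated at 40 nM, with a range from 8 nM to 200 nM. That estimate is expected to mean a 250-fold lower number from compound 2 to compound 4 (2.39 log units; beyond the scatter).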

Compound 4, half-maximal effective concentration: 1040 nM
Compound 4: middle estimate off by 26-fold (1.41 log units), on the low side; the whole stated range lies below it.
By their numbers in this assay, from the lowest: compound 1; then compound 3; then compound 4; then compound 2.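

In this assay, 4-aminobutyl in place of 1-phenylethyl recovers only part of the lost ground (a 9.5-fold lower number from compound 2 to compound 4 (0.98 log units; beyond the scatter)), so removing the aromatic ring at this amide-type nitrogen does not by itself return the number to that of compound 1. A ringless chain with a hydrogen-bond donor and acceptor is also no match for 2-hydroxyethyl (a 43-fold higher number from compound 1 to compound 4 (1.64 log units; beyond the scatter)). It even falls behind the all-carbon 1,4-dimethylpentyl group (a 5.5-fold higher number from compound 3 to compound 4 (0.74 log units; beyond the scatter)), so having a donor and acceptor on the chain does not alone set the order of these groups. No measurement offered here explains these differences.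

The step from compound 1 to compound 4 alters both chain length and end group, which leaves their separate contributions open. A 2-aminoethyl or 4-hydroxybutyl group at this nitrogen would separate the two, and a carboxylic acid at the chain end remains an open case.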